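A few compounds are considered here, and "the series" means these few. Any claim that something is new, unique, unknown or untested is made for them only; others in the source may bear on it.

Measured in a functional assay on MDA-MB-436 cells (Homo sapiens) for antiproliferative activity, read by MTT assay, with a stated time of 48 h; a lower number here means a stronger inhibitor, a higher number a weaker inhibitor:
- compound 1 `C=CS(=O)(=O)N1CCN(c2ncnc3sc(-c4ccccc4)cc23)CC1`: 21100 nM
- compound 2 `C=CS(=O)(=O)N1CCN(c2ncnc3sc(-c4ccc(C(F)(F)F)cc4)cc23)CC1`: 7080 nM
- compound 3 `C=CS(=O)(=O)N1CCN(c2ncnc3sc(-c4ccc(OC)cc4)cc23)CC1`: 28400 nM

Compound 3 gives 28400 nM, the highest of the three numbers, though methoxy in place of hydrogen gave only a 1.3-fold higher number from compound 1 to compound 3 (0.13 log units; within the scatter). Trifluoromethyl in place of hydrogen gave a 3.0-fold lower number from compound 1 to compound 2 (0.47 log units; beyond the scatter), and methoxy in place of trifluoromethyl gave a 4.0-fold higher number from compound 2 to compound 3 (0.60 log units; beyond the scatter). Compound 4 `C=CS(=O)(=O)N1CCN(c2ncnc3sc(-c4ccc(C#N)cc4)cc23)CC1` differs from compound 3 in one place: cyano in place of methoxy on an aromatic carbon. Going by the values given here, no measured compound carries cyano, so these steps are only an indirect guide. Leaving methoxy behind for a group like the one in compound 2 suggests a modest drop, smaller than a 4.0-fold higher number from compound 2 to compound 3 (0.60 log units; beyond the scatter). The expected change is a 2.4-fold lower number from compound 3 to compound 4 (0.37 log units; beyond the scatter). For compound 4 the estimated value is 12000 nM, with an expected range of 5000 nM to 28000 nM.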

Compound 4, half-maximal inhibitory concentration: 9170 nM
Compound 4: the middle estimate sits 1.3-fold (0.12 log units) above what was measured; measured number inside the range.
By their numbers in this assay, from the lowest: compounds 2 and 4 (each within the scatter of the next); then compounds 1 and 3 (each within the scatter of the next).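

Cyano at this place, para to a large group, gives a lower number than hydrogen (a 2.3-fold lower number from compound 1 to compound 4 (0.36 log units; beyond the scatter)) and than methoxy (a 3.1-fold lower number from compound 3 to compound 4 (0.49 log units; beyond the scatter)), yet it cannot be told apart from trifluoromethyl (a 1.3-fold higher number from compound 2 to compound 4 (0.11 log units; within the scatter)). The gain over hydrogen is therefore no longer tied to trifluoromethyl alone, since two different groups now reach it. Nothing measured here explains this shared gain.

From the compounds shown here alone, whether an amine or a carboxylic acid at this position would side with cyano and trifluoromethyl or with methoxy and hydrogen remains open.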